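Bromo to Chloro on the Anilide Ring of Compound 1

This account rests on a few compounds, and the source may have more. Where it says the series, first, only, none or still open, it means among the compounds named here.

Three compounds have been measured in a functional assay on A549 cells (Homo sapiens) for inhibition, read by CCK-8 assay, with a stated time of 72 h, tested at 10 uM; a lower number here means less inhibition of growth, a higher number more inhibition of growth at the concentration tested:

compound 1, `CN(C)C(=O)c1cc2cnc(Nc3ccc(NC(=O)C4(C(=O)Nc5cccc(Br)c5)CC4)cc3)nc2n1C1CCCC1`, gives 92.2%
compound 2, `Cc1ccc(NC(=O)C2(C(=O)Nc3ccc(Nc4ncc5cc(C(=O)N(C)C)n(C6CCCC6)c5n4)cc3)CC2)cc1`, gives 90.6%
compound 3, `CN(C)C(=O)c1cc2cnc(Nc3ccc(NC(=O)C4(C(=O)Nc5cccc(F)c5)CC4)cc3)nc2n1C1CCCC1`, gives 91.8%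

Compound 1 has the highest of the three numbers, but the gap to compound 3 is a number 0.4 percentage points lower from compound 1 to compound 3 (within the scatter) and the gap to compound 2 is a number 1.6 percentage points lower from compound 1 to compound 2 (within the scatter), both within the scatter, so the three stand together.

Compound 4, `CN(C)C(=O)c1cc2cnc(Nc3ccc(NC(=O)C4(C(=O)Nc5ccc(Cl)cc5)CC4)cc3)nc2n1C1CCCC1`, has not yet been measured. It differs from compound 1 by 4-chlorophenyl in place of 3-bromophenyl on an amide-type nitrogen. All three known steps change this same ring on the amide-type nitrogen: a number 1.6 percentage points lower from compound 1 to compound 2 (within the scatter), a number 0.4 percentage points lower from compound 1 to compound 3 (within the scatter) and a number 1.2 percentage points higher from compound 2 to compound 3 (within the scatter), none of them beyond the scatter. The shared core appears to carry the growth inhibition, while the ring on the amide-type nitrogen was varied without visible effect among compounds 1, 2 and 3.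

Compound 4 is therefore expected to show no step beyond the scatter, a number 1.2 percentage points lower from compound 1 to compound 4 (within the scatter), in this assay. The estimate for compound 4 is 91%, with a range from 84% to 96%.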

Compound 4, percent growth inhibition at one concentration: 101%
Compound 4: middle estimate off by 10 percentage points, on the low side; measured number above the stated range.
By their numbers in this assay, from the lowest: compounds 2, 3, 1 and 4 (each within the scatter of the next, the first and the last beyond it).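

In this assay the ring on the amide-type nitrogen now gives its first step beyond the scatter, with a number 10.4 percentage points higher from compound 2 to compound 4 (beyond the scatter) for chloro in place of methyl on an aromatic carbon. Against the other two rings no such step appears, with a number 8.8 percentage points higher from compound 1 to compound 4 (within the scatter) and a number 9.2 percentage points higher from compound 3 to compound 4 (within the scatter), so 4-chlorophenyl cannot be told apart from 3-bromophenyl or 3-fluorophenyl, and only 4-methylphenyl in compound 2 separates from it. No measurement at hand bears on why this one step appears.

From the compounds shown here alone, it remains open whether chloro itself or its place on the ring matters, which 3-chlorophenyl or 4-bromophenyl on the same nitrogen could help settle. Also open, going by these compounds, is what an amine or a carboxylic acid on this ring would do to the number.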